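The compounds below may be only part of what the source reports. "The series", "measured", "known", "first", "only" and "open" are said of these compounds alone.

Of the compounds shown here, three built on one shared core have so far been measured in an assay on CHO cells for displacement of a labelled ligand from adenosine receptor A3 (Homo sapiens), read by scintillation counting, with a stated time of 60 min; a higher number here means a weaker inhibitor, a lower number a stronger inhibitor. Compound 1 `CNC(=O)[C@@]12C[C@@H]1[C@@H](n1cnc3c(NC)nc(C#Cc4cnn(C)c4)nc31)[C@H](O)[C@@H]2O` gives 2.34 nM. Compound 2 `CNC(=O)[C@@]12C[C@@H]1[C@@H](n1cnc3c(NC)nc(C#Cc4cc5ccccc5o4)nc31)[C@H](O)[C@@H]2O` gives 1.62 nM. Compound 3 `CNC(=O)[C@@]12C[C@@H]1[C@@H](n1cnc3c(NC)nc(C#Cc4nccs4)nc31)[C@H](O)[C@@H]2O` gives 2.1 nM. On these numbers compound 3 stands second highest of the three: its nearest neighbour is reached by a 1.1-fold lower number from compound 1 to compound 3 (0.05 log units; within the scatter) and its furthest by a 1.3-fold higher number from compound 2 to compound 3 (0.11 log units; within the scatter), while the remaining pair, a 1.4-fold lower number from compound 1 to compound 2 (0.16 log units; within the scatter), is likewise within the scatter. Compound 4 `CNC(=O)[C@@]12C[C@@H]1[C@@H](n1cnc3c(NC)nc(C#CC4CC4)nc31)[C@H](O)[C@@H]2O` has not yet been measured. It differs from compound 3 in a single place: cyclopropyl in place of 1,3-thiazol-2-yl on a triple-bonded carbon. All three measured steps exchange one ring for another on the same triple-bonded carbon, and none of them shifted the number beyond the scatter, so there is no measured case in which this position mattered. The step to compound 4 is therefore expected to be small as well, though the entering ring is not aromatic, which leaves some extra uncertainty. The estimate for compound 4 is 3.5 nM, within 1.2 nM to 12 nM. That corresponds to an expected step of a 1.7-fold higher number from compound 3 to compound 4 (0.22 log units; within the scatter).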

Compound 4, inhibition constant: 1.15 nM
Compound 4: the middle estimate sits 3.0-fold (0.48 log units) above what was measured; measured number below the stated range.
By their numbers in this assay, from the lowest: compounds 4, 2, 3 and 1 (each within the scatter of the next, the first and the last beyond it).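

Compound 4 shows that this triple-bonded carbon does not need an aromatic ring or any hetero atom: cyclopropyl, a three-membered ring of carbon only with no hydrogen-bond acceptors, stays within the scatter of the two larger aromatic rings it was compared with here (a 1.8-fold lower number from compound 3 to compound 4 (0.26 log units; within the scatter); a 1.4-fold lower number from compound 2 to compound 4 (0.15 log units; within the scatter)). Among the compounds shown here, the comparison with 1-methyl-1H-pyrazol-4-yl gives the first step at this position that is printed as beyond the scatter, though only modestly (a 2.0-fold lower number from compound 1 to compound 4 (0.31 log units; beyond the scatter)). Nothing measured here explains why this exchange shifts the number.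

As far as these compounds go, all four compounds carry a ring at this place, so what an open longer chain would do on the triple-bonded carbon remains unknown. The same holds for a chain ending in an amine or a carboxylic acid.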